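The compounds below may be only part of what the source reports. "The series", "measured", "known", "first", "only" and "open" are said of these compounds alone.

Among the measured compounds shown here, the three compounds measured so far share one core, each carrying a different aromatic group. In an assay on isolated protein for agonist activity at Bile acid receptor (Homo sapiens), read by AlphaScreen, with a stated time of 30 min (a lower number here means that less compound is needed, a higher number that more compound is needed for the effect), compound 1, `Cc1ccccc1-n1nc(C)c2c1NC(=O)[C@H](C)S[C@@H]2c1ccc(-c2ccoc2)cc1`, gives 3500 nM. Compound 2, `COc1ccccc1-n1nc(C)c2c1NC(=O)[C@H](C)S[C@@H]2c1ccc(Oc2ccccc2)cc1`, gives 3300 nM in this assay, a number so close to that of compound 1 that the two cannot be told apart given the usual spread of repeated measurements. Compound 3, `COc1ccc(C2SC(C)C(=O)Nc3c2c(C)nn3-c2ccccc2C)c(OC)c1`, gives 10500 nM in this assay, a clearly higher number, so more of it is needed for the same effect. Compound 1 thus sits with compound 2 at the lower end of the three numbers, with compound 3 standing apart above them.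

Compound 4, `COc1cccc(-c2ccc([C@H]3S[C@@H](C)C(=O)Nc4c3c(C)nn4-c3ccccc3C)cc2)c1`, has not yet been measured. It differs from compound 1 in one place: 3-methoxyphenyl in place of furan-3-yl on an aromatic carbon. For the measured compounds named here, no measured pair shows this exact exchange, so the expected size of the step cannot be read from a precedent. Compound 2 does show that a larger aromatic group at the same place is tolerated, since compound 2 gives 3300 nM in this assay. The step from compound 1 to compound 4 is therefore expected to be small, a 1.4-fold lower number from compound 1 to compound 4 (0.15 log units; within the scatter), and possibly not beyond the scatter. For compound 4 the estimated value in this assay is 2500 nM, within a range from 800 nM to 8000 nM.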

Compound 4, half-maximal effective concentration: 1800 nM
Compound 4: the middle estimate sits 1.4-fold (0.14 log units) above what was measured; the range from low to high includes it.
By their numbers in this assay, from the lowest: compounds 4, 2 and 1 (each within the scatter of the next); then compound 3.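

Among the compounds shown here, replacing furan-3-yl with 3-methoxyphenyl, on an aromatic carbon para to a large group, is the first change here that can be read on its own, as no earlier pair of compounds differed in only one place. In this assay the exchange gives a 1.9-fold lower number from compound 1 to compound 4 (0.29 log units; within the scatter), even though a group of 8 heavy atoms with a six-membered ring enters where a group of 5 heavy atoms with a five-membered ring leaves, so this position accepts that larger ring without a change that can be told from the scatter. Nothing measured here offers an explanation for this result.

The compounds shown leave open whether the methoxy group contributes anything, as a plain phenyl group at this place would show, and whether moving it to another carbon of the ring would matter. On these data alone, it also remains open how this position responds to a group of a different kind, such as an amine or a carboxylic acid on that ring.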